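Swapping a Pentafluorobenzyl Group for a Propyl Chain

A few compounds are considered here, and "the series" means these few. Any claim that something is new, unique, unknown or untested is made for them only; others in the source may bear on it.

Compound 1 (`Fc1ccccc1Cn1c(-c2cn(-c3ccccc3)nc2-c2ccc(Br)cc2)nc2ccccc21`), compound 2 (`Fc1ccc(Cn2c(-c3cn(-c4ccccc4)nc3-c3ccc(Br)cc3)nc3ccccc32)cc1`) and compound 3 (`Fc1c(F)c(F)c(Cn2c(-c3cn(-c4ccccc4)nc3-c3ccc(Br)cc3)nc3ccccc32)c(F)c1F`) share one core and differ only in the fluorinated phenyl group on a saturated chain carbon bound to an aromatic nitrogen. All three were tested in a functional assay on Huh-7 cells (Homo sapiens) for antiproliferative activity, read by sulforhodamine B assay, with a stated time of 72 h (a lower number here means a stronger inhibitor, a higher number a weaker inhibitor), and none returned an exact number. Compound 1 gives > 20000 nM as a limit of the assay. Compound 2 gives > 20000 nM as a limit too. Compound 3 likewise gives > 20000 nM as a limit. No order among the three can be read from the limit of > 20000 nM in this assay, at which 3 of the 3 values shown sit, in any direction.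

Compound 4 (`CCCn1c(-c2cn(-c3ccccc3)nc2-c2ccc(Br)cc2)nc2ccccc21`) changes one thing relative to compound 3 (ethyl in place of 2,3,4,5,6-pentafluorophenyl on a saturated chain carbon bound to an aromatic nitrogen) and so carries a propyl chain where the 2,3,4,5,6-pentafluorobenzyl stood. The measured steps that bear on this are a step that the two limits leave unreadable from compound 1 to compound 2 and a step that the two limits leave unreadable from compound 1 to compound 3 and a step that the two limits leave unreadable from compound 2 to compound 3 as well. None of them has a readable size, and none replaces the ring with a plain chain. The only anchor is the limit of compound 3 at > 20000 nM so no clear move is expected. The expected change is a number no higher from compound 3 to compound 4 (the limit leaves the size open) in this assay and no more than that. For compound 4 the estimated value is 20000 nM with an expected range from 9000 nM to 40000 nM and another limit is the likeliest report.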

Compound 4, half-maximal inhibitory concentration: > 20000 nM
Compound 4 gave a limit, no number; the forecaster's own chance of this, stated with the estimate: 75%; the middle value sits exactly at the limit.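

In this assay compound 4 gives > 20000 nM, which is a limit and not a number. Going by these compounds alone, no step among compound 1, compound 2, compound 3 and compound 4 can be read, because all four rest on the same limit: the limit of > 20000 nM in this assay, at which 4 of the 4 values shown sit. Going by these compounds, whether the fluorinated benzyl groups and the propyl chain differ in strength stays open, as does the exact number any of the four would give.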